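This account rests on a few compounds, and the source may have more. Where it says the series, first, only, none or still open, it means among the compounds named here.

Compound 1, `O=C1O[C@H]([C@@H](O)Cn2cc(-c3ccc(Br)cc3)nn2)C(OCc2ccccc2)=C1OCc1ccccc1`, gives 3760 nM in a functional assay on SW-620 cells (Homo sapiens) for antiproliferative activity, read by MTT assay, with a stated time of 72 h; a higher number here means a weaker inhibitor, a lower number a stronger inhibitor.
Compound 2, `CC(C)(C)c1cn(C[C@H](O)[C@H]2OC(=O)C(OCc3ccccc3)=C2OCc2ccccc2)nn1`, gives 35800 nM in this assay.

Among the compounds with values here, compound 2 stands at the highest of the two numbers measured, so it is the weaker inhibitor of the pair; its only neighbour is compound 1, and the single measured step between them, a 9.5-fold higher number from compound 1 to compound 2 (0.98 log units; beyond the scatter), is the one that bears on what follows. Compound 3, `O=C1O[C@H]([C@@H](O)Cn2cc(-c3cc(F)cc(F)c3)nn2)C(OCc2ccccc2)=C1OCc1ccccc1`, differs from compound 2 by 3,5-difluorophenyl in place of tert-butyl on an aromatic carbon. This change undoes the kind of swap seen in that step: where tert-butyl replacing 4-bromophenyl made the number rise, putting an aromatic ring back on the same carbon is expected to bring the number down again in this assay, by a step roughly matching the measured one, though the two fluorines make the ring a different one from that in compound 1. Compound 3 is therefore expected to give about 5000 nM, with a likely range from 2000 nM to 15000 nM, a change of a 7.2-fold lower number from compound 2 to compound 3 (0.85 log units; beyond the scatter).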

Compound 3, half-maximal inhibitory concentration: > 100000 nM
Compound 3: a limit, no number (the forecaster's own chance of this, stated with the estimate: 5%); at least 20-fold (1.30 log units) between middle value and limit.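

Compound 3 has no number in this assay, only a limit of the assay: the limit of > 100000 nM in this assay, at which 1 of the 3 values shown sits. An aromatic ring on this carbon is therefore not enough on its own to give the stronger inhibitor, since 3,5-difluorophenyl in place of tert-butyl gives an at least 2.7-fold higher number from compound 2 to compound 3 (0.44 log units; beyond the scatter). Which ring sits there matters a great deal, as 3,5-difluorophenyl in place of 4-bromophenyl gives an at least 26-fold higher number from compound 1 to compound 3 (1.42 log units; beyond the scatter), a large step for a change at this one place on the shared core.

The compounds shown cannot separate the effect of gaining the two fluorines from that of losing the bromine, or tell whether the sites of these atoms on the ring matter. On these data alone, how an unsubstituted phenyl ring, a 4-fluorophenyl ring, an amine or a longer alkyl chain on this carbon would behave also stays open.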